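This account rests on a few compounds, and the source may have more. Where it says the series, first, only, none or still open, it means among the compounds named here.

Measured in a functional assay on PBMC cells (Homo sapiens) for inhibition, read by HTRF, with stated times of 15 min and 24 h; a lower number here means a stronger inhibitor, a higher number a weaker inhibitor:
- compound 1 `O=C(Nc1ccc2c(c1)B(O)OC2)c1ccccc1Cl`: > 100000 nM, a limit of the assay and not a number
- compound 2 `O=C(Nc1ccc2c(c1)B(O)OC2)c1c(F)cccc1C(F)(F)F`: 370 nM

Among the measured compounds shown here, compound 2 is the only compound with a number, 370 nM. For the measured compounds named here, its one comparator gives no number. Compound 1 stands at a limit, > 100000 nM.

Compound 3 `O=C(Nc1ccc2c(c1)B(O)OC2)c1c(F)cccc1Cl` is the next compound to be read. It differs from compound 2 by chloro in place of trifluoromethyl on an aromatic carbon, ortho to a large group and meta to a fluoro group.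

Going by the values given here, no measured step between two compounds that differ in one place is available, so the size of this change in this assay is unseen. Compound 1 also carries chloro and shows only its limit, > 100000 nM. A moderate move towards a weaker inhibitor is expected, beyond the scatter, with a measurable number still likely. The estimated change is a 2.7-fold higher number from compound 2 to compound 3 (0.43 log units; beyond the scatter). For compound 3 the expected value is 1000 nM, with an estimated range of 200 nM to 6000 nM.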

Compound 3, half-maximal inhibitory concentration: 4900 nM
Compound 3: the middle estimate sits 4.9-fold (0.69 log units) below what was measured; low and high end bracket the measured number.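

In this assay, among the compounds shown here, the first step with a number at this position is a 13-fold higher number from compound 2 to compound 3 (1.12 log units; beyond the scatter). With the fluoro group held in place, chloro in place of trifluoromethyl therefore weakens inhibition substantially, yet still leaves a measurable number. The second step, an at least 20-fold lower number from compound 1 to compound 3 (1.30 log units; beyond the scatter), shows that with chloro held in place, fluoro in place of hydrogen on an aromatic carbon brings compound 3 into the measurable range, although the size of this step is bounded by a limit of the assay and is not an exact difference: the limit of > 100000 nM in this assay, at which 1 of the 3 values shown sits.

The compounds shown leave open whether another group in the place of trifluoromethyl, such as methyl, methoxy or nitrile, would match compound 2 or exceed it. Also open, from the compounds shown here alone, are the size of the step for fluoro in place of hydrogen with trifluoromethyl held in place, and the effect of an amine in place of the fluoro group.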